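The source may hold more compounds than are shown below. What is called first, only, known or untested is meant among the compounds shown, and "the series" means these compounds.

Compounds measured so far:
- compound 1, `CC(=O)Nc1c(C(O)(C(F)(F)F)C(F)(F)F)ccc2ccccc12`: 95.5 nM
- compound 2, `C/C=C/C(=O)Nc1c(C(O)(C(F)(F)F)C(F)(F)F)ccc2ccccc12`: 49 nM

Both compounds share the same core and were tested in a functional assay (Sus scrofa) with sulfonylurea receptors; K-ATP channels (Homo sapiens) as the target; a higher number here means that more compound is needed for the effect, a lower number that less compound is needed. For the measured compounds named here, compound 2 stands at the low end of the two numbers, but the only measured step, a 1.9-fold lower number from compound 1 to compound 2 (0.29 log units; within the scatter), is within the scatter, so the two compounds cannot be told apart on this evidence. That step exchanged a methyl group for a prop-1-en-1-yl group on the carbonyl carbon of the amide.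

Compound 3, `COCC(=O)Nc1c(C(O)(C(F)(F)F)C(F)(F)F)ccc2ccccc12`, has not yet been measured. It differs from compound 2 as follows: methoxymethyl in place of prop-1-en-1-yl on a carbonyl carbon. Going by the values given here, the one measured change at this carbonyl carbon, from compound 1 to compound 2, stayed within the scatter, and no measured compound carries a methoxymethyl group anywhere, so there is no direct guide for this exchange. On that basis the step of a 1.4-fold higher number from compound 2 to compound 3 (0.15 log units; within the scatter) is expected to stay within the scatter, with no clear direction. In this assay compound 3 is therefore estimated at 70 nM, with a likely range from 25 nM to 250 nM.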

Compound 3, half-maximal effective concentration: 204 nM
Compound 3: middle estimate off by 2.9-fold (0.46 log units), on the low side, within the range that was stated.
By their numbers in this assay, from the lowest: compounds 2 and 1 (each within the scatter of the next); then compound 3.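

The carbonyl carbon of the amide now proves sensitive to what it carries, which the first two compounds could not show because their exchange of methyl for prop-1-en-1-yl stayed within the scatter. In this assay the change to methoxymethyl gives a 4.2-fold higher number from compound 2 to compound 3 (0.62 log units; beyond the scatter) and so needs more compound, a modest but readable shift. The same direction appears when a methoxy group replaces a hydrogen on the saturated carbon of the small acetyl chain, with a 2.1-fold higher number from compound 1 to compound 3 (0.33 log units; beyond the scatter) as the result, so among these three compounds the one chain holding an oxygen and a hydrogen-bond acceptor has the highest number. No measurement shown here explains why this oxygen-bearing chain needs more compound.

A propyl chain, with carbon where compound 3 carries its oxygen, would help to show whether the rise goes with the oxygen itself or with the loss of the double bond present in compound 2. On these data alone, how a hydroxymethyl group, an amine or a longer ether chain would behave on this carbonyl carbon remains open.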